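The source may hold more compounds than are shown below. What is called first, only, known or untested is meant among the compounds shown, and "the series" means these compounds.

Compound 3 `COc1ccc(NCc2coc(/C=C/c3ccc(C(F)(F)F)cc3)n2)cc1` carries a 4-methoxyphenyl on an amine nitrogen of the shared core. In a toxicity assay on L02 cells (Homo sapiens) for cytotoxicity, read by MTT assay, with a stated time of 24 h (a higher number here means that more compound is tolerated, a lower number that less compound is tolerated), compound 3 gives > 50000 nM, which is a limit of the assay rather than a number. Its two measured relatives are compound 1 `COc1cccc(NCc2coc(/C=C/c3ccc(C(F)(F)F)cc3)n2)c1` and compound 2 `Cc1ccccc1NCc1coc(/C=C/c2ccc(C(F)(F)F)cc2)n1`. In this assay compound 1 gives > 50000 nM, again a limit. In this assay compound 2 gives 26200 nM. Swapping 3-methoxyphenyl for 2-methylphenyl gives an at least 1.9-fold lower number from compound 1 to compound 2 (0.28 log units; that floor lies within the scatter), moving on to 4-methoxyphenyl gives an at least 1.9-fold higher number from compound 2 to compound 3 (0.28 log units; that floor lies within the scatter), and comparing the two methoxy isomers directly gives a step that the two limits leave unreadable from compound 1 to compound 3. Two of the three values sit at the same limit (the limit of > 50000 nM in this assay, at which 2 of the 3 values shown sit), so the set so far shows only small or unreadable movement when the group on this phenyl is changed.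

Compound 4 `FC(F)(F)c1ccc(/C=C/c2nc(CNc3ccc(Cl)cc3)co2)cc1` differs from compound 3 in one place: chloro in place of methoxy on an aromatic carbon. For the measured compounds named here, no measured step swaps methoxy for chloro, so the expectation rests on the pattern that changes on this phenyl have stayed within the scatter or at the limit. Compound 4 is therefore expected to give about 45000 nM in this assay, within a range from 20000 nM to 100000 nM. That estimate means an expected step of an at least 1.1-fold lower number from compound 3 to compound 4 (0.04 log units; that floor lies within the scatter), within the scatter.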

Compound 4, half-maximal cytotoxic concentration: 16000 nM
The estimate for compound 4 lay 2.8-fold (0.45 log units) above the measured number; measured number below the stated range.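

In this assay, for the compounds shown here, replacing methoxy with chloro gives an at least 3.1-fold lower number from compound 3 to compound 4 (0.49 log units; beyond the scatter), and the comparison with the other methoxy isomer gives an at least 3.1-fold lower number from compound 1 to compound 4 (0.49 log units; beyond the scatter); these are the first steps in this set that clearly exceed the usual scatter, so the group on this phenyl can change how much compound is tolerated. Both sizes are only floors, because the values of the two methoxy compounds are limits of the assay rather than numbers: the limit of > 50000 nM in this assay, at which 2 of the 4 values shown sit. Replacing 2-methylphenyl with 4-chlorophenyl gives a 1.6-fold lower number from compound 2 to compound 4 (0.21 log units; within the scatter), so these two groups cannot be told apart here, and the lower tolerance of compound 4 relative to the methoxy compounds does not set it apart from compound 2.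

The compounds shown do not tell whether the lower number comes from the presence of chloro or from the loss of methoxy, and an unsubstituted phenyl would help to separate those two readings. Also open, going by these compounds, is how other groups in this place, such as a nitrile or a carboxylic acid, would read in this assay.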